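Swapping the hydroxy-methoxy ring for a trimethoxy ring

A few compounds are considered here, and "the series" means these few. Any claim that something is new, unique, unknown or untested is made for them only; others in the source may bear on it.

Measured compounds:
compound 1 `COc1cc(/C=C/C(=O)c2cccc(-n3cc(-c4ccccc4)[nH]c3=O)c2)cc(OC)c1OC` 1230 nM
compound 2 `COc1ccc(-c2cn(-c3cccc(C(=O)/C=C/c4ccc(O)c(OC)c4)c3)c(=O)[nH]2)cc1` 2700 nM

In a functional assay on OVCAR-3 cells (Homo sapiens) for inhibition (a higher number here means a weaker inhibitor of growth, a lower number a stronger inhibitor of growth), compound 2 gives the higher of the two numbers, with compound 1 sitting below it by a gap beyond the usual scatter. Compound 3 `COc1ccc(-c2cn(-c3cccc(C(=O)/C=C/c4cc(OC)c(OC)c(OC)c4)c3)c(=O)[nH]2)cc1` differs from compound 2 by 3,4,5-trimethoxyphenyl in place of 4-hydroxy-3-methoxyphenyl on a double-bonded chain carbon bound to a double-bonded chain carbon. Among the measured compounds shown here, no direct step between measured compounds carries this change, so the expectation leans on the weaker evidence that compound 1, which also carries a 3,4,5-trimethoxyphenyl on that chain, gives 1230 nM. The step of a 2.1-fold lower number from compound 2 to compound 3 (0.32 log units; beyond the scatter) is expected to be modest and toward a lower number. Compound 3 is therefore estimated at 1300 nM, within the range 500 nM to 3500 nM.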

Compound 3, concentration for 50% growth inhibition: 1780 nM
For compound 3 the middle estimate is 1.4-fold (0.14 log units) below the measured one; measured number inside the range.
By their numbers in this assay, from the lowest: compounds 1, 3 and 2 (each within the scatter of the next, the first and the last beyond it).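

In this assay, 3,4,5-trimethoxyphenyl in place of 4-hydroxy-3-methoxyphenyl gives a 1.5-fold lower number from compound 2 to compound 3 (0.18 log units; within the scatter), so losing the hydrogen-bond donor of this ring makes no difference that this read-out can resolve. Methoxy in place of hydrogen on an aromatic carbon gives a 1.4-fold higher number from compound 1 to compound 3 (0.16 log units; within the scatter), so that change cannot be told apart from the scatter either. Nothing available explains either result. Still open, going by these compounds, is whether an amine or a carboxylic acid on the ring at this position would shift growth inhibition beyond the scatter.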